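Lengthening an Ether Linker in a Series of Allosteric Modulators

The source may hold more compounds than are shown below. What is called first, only, known or untested is meant among the compounds shown, and "the series" means these compounds.

Compound 1, `Fc1ccccc1C1CCN(Cc2ccn3c(CC4CC4)nnc3c2C(F)(F)F)CC1`: 15 nM
Compound 2, `Fc1cccc(F)c1C1CCN(Cc2ccn3c(CC4CC4)nnc3c2C(F)(F)F)CC1`: 9.7 nM
Compound 3, `Fc1ccc(OC2CCN(Cc3ccn4c(CC5CC5)nnc4c3C(F)(F)F)CC2)c(F)c1`: 57 nM

In an assay on CHO cells for positive allosteric modulation of metabotropic glutamate receptor 2 (Homo sapiens), read by scintillation counting, with a stated time of 30 min (a higher number here means that more compound is needed for the effect, a lower number that less compound is needed), compound 3 stands at the highest of the three numbers: the steps of a 3.8-fold higher number from compound 1 to compound 3 (0.58 log units; beyond the scatter) and a 5.9-fold higher number from compound 2 to compound 3 (0.77 log units; beyond the scatter) both lie beyond the scatter, whereas a 1.5-fold lower number from compound 1 to compound 2 (0.19 log units; within the scatter) does not. Compound 4, `Fc1ccc(COC2CCN(Cc3ccn4c(CC5CC5)nnc4c3C(F)(F)F)CC2)c(F)c1`, differs from compound 3 by 2,4-difluorobenzyl in place of 2,4-difluorophenyl on an oxygen on a saturated carbon. Among the compounds with values here, no measured step tests this change directly; the nearest precedents are the two steps leading into compound 3, which each lengthened the link between the saturated ring and the aromatic ring and raised the number modestly. A further lengthening is therefore expected to give only a small step, a 1.6-fold higher number from compound 3 to compound 4 (0.20 log units; within the scatter), upward or within the scatter. Compound 4 is estimated at 90 nM, with a range from 30 nM to 300 nM.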

Compound 4, half-maximal effective concentration in the metabotropic glutamate receptor 2 assay: 57 nM
For compound 4 the middle estimate is 1.6-fold (0.20 log units) above the measured one, within the range that was stated.
By their numbers in the metabotropic glutamate receptor 2 assay, from the lowest: compounds 2 and 1 (each within the scatter of the next); then compounds 3 and 4 (each within the scatter of the next).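

In the metabotropic glutamate receptor 2 assay the oxygen on the saturated carbon accepts 2,4-difluorobenzyl in place of 2,4-difluorophenyl without a readable shift, with no change at the digits printed from compound 3 to compound 4 (within the scatter). The lengthened link does not close the gap to the compounds with the aromatic ring on the saturated ring carbon, with a 5.9-fold higher number from compound 2 to compound 4 (0.77 log units; beyond the scatter) and a 3.8-fold higher number from compound 1 to compound 4 (0.58 log units; beyond the scatter). In a physicochemical assay for solubility, read by HPLC, measured as kinetic solubility, at pH 4 (a higher number here means a more soluble compound, a lower number a less soluble compound), compound 3 gives > 100000 nM as a limit of the assay. In the physicochemical assay compound 4 gives > 100000 nM as a limit of the assay. In the physicochemical assay the step cannot be read, and both values are limits: the limit of > 100000 nM in the physicochemical assay, at which 2 of the 2 values shown sit.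

Going by these compounds, whether a longer chain on this oxygen would also leave the number in the metabotropic glutamate receptor 2 assay unchanged stays open. So does the effect of an amine or a carboxylic acid on the aromatic ring.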